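This account rests on a few compounds, and the source may have more. Where it says the series, first, only, none or still open, it means among the compounds named here.

Measured in an assay on Sf9 cells for inhibition of protein deacetylase HDAC6 (Homo sapiens), read by fluorescence, with a stated time of 90 min; on this read-out lower numbers stand for stronger inhibition and higher numbers for weaker inhibition:
compound 1, `CN(C)c1ccc(C(=O)N(CCCCCC(=O)Nc2cc(F)ccc2N)CC(=O)NCc2ccccc2)cc1`, gives > 10000 nM.
compound 2, `Nc1ccccc1NC(=O)CCCCCN(CC(=O)NCc1ccccc1)C(=O)c1cccc2ccccc12`, gives > 10000 nM.
compound 3, `Cc1cc(C)cc(C(=O)N(CCCCCC(=O)Nc2ccccc2N)CC(=O)NCc2ccccc2)c1`, gives > 10000 nM.

Each of these three values is a limit of the assay, not a number. Compound 3 therefore stands at the limit of > 10000 nM in this assay, at which 3 of the 3 values shown sit, together with the other two compounds, and nothing more precise about its place is known. Going by the values given here, the only step among them that changes one place, a step that the two limits leave unreadable from compound 2 to compound 3, cannot be read because both ends are limits.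

Compound 4, `CN(C)c1ccc(C(=O)N(CCCCCC(=O)Nc2ccccc2N)CC(=O)NCc2ccccc2)cc1`, differs from compound 3 by 4-(dimethylamino)phenyl in place of 3,5-dimethylphenyl on a carbonyl carbon. Among the compounds with values here, no measured step is readable that bears on this change. Compound 1 carries the same 4-(dimethylamino)phenyl group on the carbonyl carbon, and its value in this assay is a limit. On this basis no step beyond the scatter is expected in either direction, and compound 4 is expected most likely to remain at the limit as well, with an estimated step that the limit leaves unreadable from compound 3 to compound 4. The estimate for compound 4 in this assay is 20000 nM, in a range from 6000 nM to 80000 nM.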

Compound 4, half-maximal inhibitory concentration: > 10000 nM
Compound 4: only a limit was reported; the forecaster's own chance of this, stated with the estimate: 85%; the middle value lies beyond the limit too.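

In this assay compound 4 gives > 10000 nM, which is a limit of the assay. No step from compound 1, compound 2 or compound 3 to compound 4 can be read, and all four compounds share one place: the limit of > 10000 nM in this assay, at which 4 of the 4 values shown sit.

The compounds shown leave open how strongly any of them inhibits, and whether any of these changes alters that inhibition.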